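This account rests on a few compounds, and the source may have more. Where it says the series, first, only, none or still open, it means among the compounds named here.

In a physicochemical assay for lipophilicity, read by HPLC, using the shake flask method (a lower number here means a more polar compound, a higher number a more lipophilic compound), compound 1 `CCCCCN(Cc1ccc(Cl)nc1)/C(C)=N/C#N` gives 2.37, the highest of the three measured numbers. Compound 3 `CN(Cc1ccc(Cl)nc1)/C(=N/C#N)c1ccccc1` gives 1.86, and compound 2 `CCC/C(=N\C#N)N(C)Cc1ccc(Cl)nc1` gives 1.55. Going by the values given here, the only single-change step measured, a number 0.31 log units higher from compound 2 to compound 3 (beyond the scatter), concerns phenyl in place of propyl on a carbon with a double bond to nitrogen and does not match the change at hand. Compound 4 `CCN(Cc1ccc(Cl)nc1)/C(C)=N/C#N` differs from compound 1 by hydrogen in place of propyl on a saturated chain carbon, two bonds along the chain from an amine nitrogen. Compound 1 and compound 2 differ in two places, so their values cannot be read as one clean step. Because compound 1 gives 2.37 with the longest chain of the three, a shorter chain in compound 4 is expected to give a step of a number 1.22 log units lower from compound 1 to compound 4 (beyond the scatter). Compound 4 is expected to read 1.15, between 0.75 and 1.55.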

Compound 4, partition coefficient: 1.19
Compound 4: middle estimate off by 0.04 log units, on the low side, within the range that was stated.
By their numbers in this assay, from the lowest: compound 4; then compound 2; then compound 3; then compound 1.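

Going by these compounds alone, the chain on the amine nitrogen had so far changed only together with another part of the molecule, and here it changes alone. In this assay, cutting pentyl to ethyl gives a number 1.18 log units lower from compound 1 to compound 4 (beyond the scatter), a large step from losing a propyl piece of the chain. Nothing measured here explains why the number moves so far. On these data alone, with only these two chain lengths compared in one clean step, it remains open whether a longer chain such as hexyl would continue the trend. As far as these compounds go, how a carboxylic acid at the chain end would read also stays open.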